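Amide acyl change on compound 1: expected outcome

The source may hold more compounds than are shown below. What is called first, only, known or untested is meant among the compounds shown, and "the series" means these compounds.

Among the measured compounds shown here, compound 1 `COc1ccc(CN(C(C)=O)c2cc(OC)c(OC)c(OC)c2)cc1O` holds the lowest of the two numbers so far: in a functional assay on MGC-803 cells (Homo sapiens) for inhibition, read by MTT assay, with a stated time of 48 h (on this read-out lower numbers stand for stronger inhibition and higher numbers for weaker inhibition), compound 1 gives 79 nM. Compound 2 `COc1ccc(CNc2cc(OC)c(OC)c(OC)c2)cc1C` gives 56800 nM in this assay, a gap well beyond the scatter. For the measured compounds named here, no single-point step between measured compounds is available, so the effect of the acyl change has no direct precedent. Compound 3 `C/C=C/C(=O)N(Cc1ccc(OC)c(O)c1)c1cc(OC)c(OC)c(OC)c1` differs from compound 1 by prop-1-en-1-yl in place of methyl on a carbonyl carbon. The step of a 1.1-fold lower number from compound 1 to compound 3 (0.05 log units; within the scatter) is expected to be none beyond the scatter, with a slight shift either way possible. Compound 3 is therefore estimated at 70 nM, with a range from 20 nM to 300 nM.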

Compound 3, half-maximal inhibitory concentration: 27 nM
For compound 3 the middle estimate is 2.6-fold (0.41 log units) above the measured one; measured number inside the range.
By their numbers in this assay, from the lowest: compound 3; then compound 1; then compound 2.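

In this assay, among the compounds shown here, prop-1-en-1-yl in place of methyl on a carbonyl carbon gives a 2.9-fold lower number from compound 1 to compound 3 (0.47 log units; beyond the scatter) as the first single-place step. The acetyl group is therefore not the limit here, since a longer acyl group carrying a double bond keeps the number low and moves it modestly further down. No measurement at hand bears on the reason for this step.

As far as these compounds go, whether the step follows the double bond or the added carbons stays open. A saturated propyl group on the carbonyl carbon would separate the two, and a carboxylic acid or an amine on the chain would probe the position further.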